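The compounds below may be only part of what the source reports. "The series", "measured", "known", "first", "only" and "open" are said of these compounds alone.

Among the compounds with values here, in an ADME assay on HepG2 cells (Homo sapiens) for cytotoxicity (on this read-out higher numbers stand for weaker inhibition and lower numbers for stronger inhibition), compound 2 `Cc1ccc(CNc2nc(C#N)cnc2C#N)cc1` gives 70800 nM, and it is the only plain number here. Compound 1 `N#Cc1cnc(C(N)=O)c(NCc2ccc(N)cc2)n1` reaches only a limit of the assay, > 1000000 nM, a point where (the limit of > 1000000 nM in this assay, at which 1 of the 2 values shown sits). Compound 3 `N#Cc1cnc(C#N)c(NCc2ccc(N)cc2)n1` is still to be measured. It differs from compound 2 by a single change, (amino in place of methyl on an aromatic carbon), in words amino in place of methyl on an aromatic carbon. Within the data shown here, with no measured step of this kind to lean on, the change is expected to leave compound 3 within the scatter or somewhat weaker, as a 2.1-fold higher number from compound 2 to compound 3 (0.33 log units; beyond the scatter). Compound 3 is therefore estimated at 150000 nM, within 40000 nM to 1000000 nM.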

Compound 3, half-maximal inhibitory concentration: 549000 nM
Estimate against measurement, compound 3: 3.7-fold (0.56 log units) below; the range from low to high includes it.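

In this assay amino in place of methyl on an aromatic carbon, para to a large group, gives a 7.8-fold higher number from compound 2 to compound 3 (0.89 log units; beyond the scatter) and so shows that this position responds to the change. The step for cyano in place of carbamoyl is an at least 1.8-fold lower number from compound 1 to compound 3 (0.26 log units; that floor lies within the scatter) and by itself establishes no clear change. Compound 1 stands at a limit, not at a plain number: the limit of > 1000000 nM in this assay, at which 1 of the 3 values shown sits.

The compounds shown leave open how methoxy or chloro at this position would compare with amino and methyl. They also leave open what a carboxylic acid in place of cyano would do.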